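This account rests on a few compounds, and the source may have more. Where it says the series, first, only, none or still open, it means among the compounds named here.

Compound 3 `Cc1cc(C#N)cc(C)c1Oc1nc(Nc2ccc(C#N)cc2)ncc1/C=C/C(=O)NCC1CCN(S(C)(=O)=O)CC1` is the starting point. In an ADME assay on TZM cells (Homo sapiens) for cytotoxicity, with a stated time of 1 days (a higher number here means that more compound is tolerated, a lower number that less compound is tolerated), compound 3 gives only a limit, > 171 nM. Compound 1 `CCOC(=O)/C=C/c1cnc(Nc2ccc(C#N)cc2)nc1Oc1c(C)cc(C#N)cc1C` likewise gives a limit in this assay, > 227 nM. Compound 2 `Cc1cc(C#N)cc(C)c1Oc1nc(Nc2ccc(C#N)cc2)ncc1/C=C/C(=O)NCCOCCO` gives a limit in this assay as well, > 200 nM. Within the data shown here, since every value shown is a limit of > 171 nM in this assay, at which 1 of the 3 values shown sits, the limit of > 200 nM in this assay, at which 1 of the 3 values shown sits (the limit of > 227 nM in this assay, at which 1 of the 3 values shown sits), none of the measured steps has a readable size: a step that the two limits leave unreadable from compound 1 to compound 2, a step that the two limits leave unreadable from compound 1 to compound 3, a step that the two limits leave unreadable from compound 2 to compound 3. Compound 3 thus stands at a limit, as the other two compounds do, and no ordering among the three can be drawn.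

Compound 4 `Cc1cc(C#N)cc(C)c1Oc1nc(Nc2ccc(C#N)cc2)ncc1/C=C/C(=O)NCC1CCN(S(C)(=O)=O)C1` differs from compound 3 in one place: 1-(methylsulfonyl)pyrrolidin-3-yl in place of 1-(methylsulfonyl)piperidin-4-yl on a saturated chain carbon bound to an amide-type nitrogen. The measured steps that bear on changes at this position are the two ending in compound 3, a step that the two limits leave unreadable from compound 1 to compound 3 and a step that the two limits leave unreadable from compound 2 to compound 3, and both are unreadable. No step beyond the scatter is therefore expected, and the most probable outcome is once more a limit. Compound 4 is expected at about 200 nM, in the range 100 nM to 400 nM. The step expected from compound 3 to compound 4 is a step that the limit leaves unreadable from compound 3 to compound 4.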

Compound 4, half-maximal cytotoxic concentration: > 175 nM
Compound 4: a limit, no number (the forecaster's own chance of this, stated with the estimate: 85%); the middle value is on the limit's open side.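

In this assay compound 4 gives the limit > 175 nM and no number, so its steps from compound 1, compound 2 and compound 3 cannot be read. What stays open is where the half-maximal cytotoxic concentration in this assay lies for any of these compounds, and whether 1-(methylsulfonyl)pyrrolidin-3-yl and 1-(methylsulfonyl)piperidin-4-yl differ at all.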